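Swapping a side group on a histamine antagonist scaffold

The source may report more compounds than this note shows. Statements on the series, on what has been measured and on what is new or still open speak of the compounds shown alone.

Measured so far:
compound 1 `CN(C)Cc1cc(OC/C=C\C/N=c2\c(O)c(O)c2=N)cs1`, 0.22 ug/mL
compound 2 `CN(C)CC/N=c1\c(O)c(O)\c1=N/C/C=C\COc1csc(CN2CCCCC2)c1`, 0.35 ug/mL
compound 3 `N#CCCNc1c(NC/C=C\COc2csc(CN3CCCCC3)c2)c(=O)c1=O`, 0.31 ug/mL

Of the compounds shown here, three have been tested in a functional assay for antagonist activity at histamine H2 receptor (Cavia porcellus); on this read-out higher numbers stand for weaker inhibition and lower numbers for stronger inhibition. Compound 1 gives 0.22 ug/mL, compound 2 gives 0.35 ug/mL and compound 3 gives 0.31 ug/mL. Compound 2 shows the highest of the three numbers, but its nearest neighbour, compound 3, sits within the scatter of it, and so does the furthest, compound 1; on these numbers the three compounds cannot be told apart.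

Compound 4 `COCC/N=c1\c(O)c(O)\c1=N/C/C=C\COc1csc(CN2CCCCC2)c1` has not yet been measured. It differs from compound 2 in one place: methoxy in place of dimethylamino on a saturated chain carbon, two bonds along the chain from a double-bonded nitrogen. For the measured compounds named here, no pair of measured compounds differs in exactly one place, so there is no measured step to lean on. What the data do show is that compound 1, compound 2 and compound 3 carry quite different groups at the same end of the shared core and still land within the scatter of one another, which argues for a small step at most in this assay.

For compound 4 the expected step is a 1.1-fold higher number from compound 2 to compound 4 (0.06 log units; within the scatter), none beyond the scatter in either direction. Compound 4 is therefore estimated at 0.4 ug/mL, with a range from 0.15 ug/mL to 1.1 ug/mL.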

Compound 4, half-maximal inhibitory concentration: 0.48 ug/mL
Estimate against measurement, compound 4: 1.2-fold (0.08 log units) below, and the stated range covers the measured number.
By their numbers in this assay, from the lowest: compounds 1, 3, 2 and 4 (each within the scatter of the next, the first and the last beyond it).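

This pair gives the first step measured at a single place in this series: in this assay, methoxy in place of dimethylamino on a saturated chain carbon, two bonds along the chain from a double-bonded nitrogen, gives a 1.4-fold higher number from compound 2 to compound 4 (0.14 log units; within the scatter). So 2-(dimethylamino)ethyl can be exchanged for 2-methoxyethyl, a nitrogen-bearing end group for an oxygen-bearing one, without the read-out leaving the scatter. The earlier compounds shown here could only hint at this, and none of them differed in just one place. Nothing available here accounts for the size of this step.

The counts of hydrogen-bond donors and acceptors are the same for both groups, so this pair cannot show what happens when the chain end carries a hydrogen-bond donor, as a hydroxyl group or a primary amine would, or a carboxylic acid. It also leaves open whether a longer chain, such as 3-methoxypropyl, would stay within the scatter of compound 4 or move beyond it.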